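The source may hold more compounds than are shown below. What is called first, only, known or untested is meant among the compounds shown, and "the series" means these compounds.

Compound 1, `CCOC(=O)c1c(-c2cccs2)[nH]c2cc(OC)ccc2c1=O`: > 100000 nM
Compound 2, `CCOC(=O)c1c(-c2ccc(OC)cc2)[nH]c2cc(OC)ccc2c1=O`: 8000 nM

Both compounds were tested in a physicochemical assay for solubility, in phosphate buffer, at pH 7.4; a lower number here means a less soluble compound, a higher number a more soluble compound. For compound 1 the result > 100000 nM is a limit of the assay rather than a number; this is the limit of > 100000 nM in this assay, at which 1 of the 2 values shown sits. In this assay, among the compounds with values here, compound 2 gives 8000 nM, the only plain number among the values shown, so it cannot be placed above or below another numbered compound. Within the data shown here, the one measured step is an at least 12-fold lower number from compound 1 to compound 2 (1.09 log units; beyond the scatter).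

Compound 3, `CCOC(=O)c1c(-c2cccc(Cl)c2)[nH]c2cc(OC)ccc2c1=O`, has not yet been measured. It differs from compound 2 in one place: 3-chlorophenyl in place of 4-methoxyphenyl on an aromatic carbon. Among the measured compounds shown here, no measured step concerns this exchange, since the only one, an at least 12-fold lower number from compound 1 to compound 2 (1.09 log units; beyond the scatter), swaps a different group, so it gives no direct guide. A modest step downwards, close to the scatter, is therefore expected: a 2.0-fold lower number from compound 2 to compound 3 (0.30 log units; within the scatter). Compound 3 is estimated at 4000 nM, with a range from 1000 nM to 15000 nM.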

Compound 3, solubility: 58000 nM
Compound 3: the middle estimate sits 15-fold (1.16 log units) below what was measured; the measured number lies above the stated range.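

In this assay, the exchange at this position, next to the ring nitrogen, gives a 7.3-fold higher number from compound 2 to compound 3 (0.86 log units; beyond the scatter). This shows that a six-membered aromatic ring of carbon only at this place does not by itself fix the number near that of compound 2: what the ring carries matters. The other new reading is an at least 1.7-fold lower number from compound 1 to compound 3 (0.23 log units; that floor lies within the scatter), and it sets no true size, as compound 1 stands at a limit rather than a number: the limit of > 100000 nM in this assay, at which 1 of the 3 values shown sits.

The compounds shown do not separate the loss of the methoxy group from the gain of the chlorine, and a plain phenyl or a 4-chlorophenyl group would be needed to tell these apart. As far as these compounds go, how an amine or a carboxylic acid on this ring would read also remains open.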